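A heptynyl chain on a series stuck at the limit

This account rests on a few compounds, and the source may have more. Where it says the series, first, only, none or still open, it means among the compounds named here.

Measured so far in an ADME assay on L1210/0 cells (Mus musculus) for cytotoxicity, with a stated time of 48 h; a higher number here means a weaker inhibitor, a lower number a stronger inhibitor
Compound 1 `COCC#Cc1cn([C@H]2C[C@H](O)[C@@H](CO)O2)c(=O)[nH]c1=O` gives > 200000 nM
Compound 2 `C#COc1cn([C@H]2C[C@H](O)[C@@H](CO)O2)c(=O)[nH]c1=O` gives > 200000 nM

Compound 2 has no number to stand on, only a limit of the assay (> 200000 nM). Compound 1 also has only a limit (> 200000 nM). The whole record so far is the limit of > 200000 nM in this assay, at which 2 of the 2 values shown sit, so neither compound can be placed above the other.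

The next compound, compound 3 `CCCCCC#Cc1cn([C@H]2C[C@H](O)[C@@H](CO)O2)c(=O)[nH]c1=O`, carries hept-1-yn-1-yl in place of ethynyloxy on an aromatic carbon.

Going by the values given here, the only measured step that bears on this change is a step that the two limits leave unreadable from compound 1 to compound 2. It swaps a group at the same place, but it gives no size that could be carried over. With so little to go on, the expectation in this assay is for weak inhibition to continue, with at most a modest move toward stronger inhibition. The expected step is an at least 1.3-fold lower number from compound 2 to compound 3 (0.12 log units; that floor lies within the scatter), and it may prove just as unreadable if another limit is reported. For compound 3 the estimated value is 150000 nM, with an expected range from 50000 nM to 400000 nM.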

Compound 3, half-maximal inhibitory concentration: > 200000 nM
Compound 3: no number, only a limit; the forecaster's own chance of this, stated with the estimate: 60%; middle value at least 1.3-fold (0.12 log units) away from the limit.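

In this assay compound 3 gives > 200000 nM as a limit of the assay, not a number. No step between compound 1, compound 2 and compound 3 can be read, because all three stop at the same limit: the limit of > 200000 nM in this assay, at which 3 of the 3 values shown sit.
The compounds shown leave open whether any of these three groups on the shared core changes inhibition at all.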